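Amide nitrogen substituent step in the series

The compounds below may be only part of what the source reports. "The series", "measured", "known", "first", "only" and "open" are said of these compounds alone.

Measured compounds:
compound 1 `CN(CC1CC1)C(=O)c1cccc(-c2cccc(-n3ncc(C(=O)O)c3C3CC3)c2)c1F` — 2200 nM
compound 2 `CCCC1CCCCN1C(=O)c1cccc(-c2cccc(-n3ncc(C(=O)O)c3C3CC3c3cccnc3)c2)c1` — 3200 nM

In an assay on BEAS-2B cells for activation of nuclear factor erythroid 2-related factor 2 (Homo sapiens), read by MTT assay, with a stated time of 48 h (a lower number here means that less compound is needed, a higher number that more compound is needed for the effect), compound 1 gives 2200 nM, the lowest of the two numbers available. Compound 2 gives 3200 nM in this assay, which lies within the scatter of compound 1, so the two cannot be ordered. For the measured compounds named here, compound 1 and compound 2 differ in several places at once, and no single step connects them; their two values alone carry no information on any one change.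

Compound 3 `O=C(O)c1cnn(-c2cccc(-c3cccc(C(=O)N(CC4CC4)CC4CC4)c3F)c2)c1C1CC1` differs from compound 1 by cyclopropyl in place of hydrogen on a saturated chain carbon bound to an amide-type nitrogen. Going by the values given here, no measured pair in the set shows this kind of change, so the expected size of the step rests only on the values at hand. The expectation is for no change beyond the scatter in this assay, in either direction. Compound 3 is therefore expected to give 2000 nM, with a range from 800 nM to 5000 nM. The estimated step of a 1.1-fold lower number from compound 1 to compound 3 (0.04 log units; within the scatter) is expected to stay within the scatter.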

Compound 3, half-maximal effective concentration: 3500 nM
Compound 3: middle estimate off by 1.8-fold (0.24 log units), on the low side, within the range that was stated.
By their numbers in this assay, from the lowest: compounds 1, 2 and 3 (each within the scatter of the next).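

The amide nitrogen now has its first single-place step: in this assay, methyl changing to cyclopropylmethyl gives a 1.6-fold higher number from compound 1 to compound 3 (0.20 log units; within the scatter) and leaves the value within the scatter. On the core of compound 1, the read-out therefore does not separate the (cyclopropylmethyl)(methyl)carbamoyl group from the bis(cyclopropylmethyl)carbamoyl group, and this single step gives no direction for the added cyclopropyl. No measurement on hand bears on the reason for this result.

From the compounds shown here alone, whether a longer chain, such as n-butyl, or a chain ending in an amine or a carboxylic acid would move the value beyond the scatter at this place remains open. Also open, going by these compounds, is whether the same change would read alike on the core of compound 2.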